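Three measured compounds, all at the assay limit

The source may report more compounds than this note shows. Statements on the series, on what has been measured and on what is new or still open speak of the compounds shown alone.

Compound 1 `Cc1ccc(Cn2cc(CSC(=S)N3CCN(C(=O)NC(C)C)CC3)nn2)cc1`: > 128000 nM
Compound 2 `CCN(C)C(=O)N1CCN(C(=S)SCc2cn(Cc3ccc(C)cc3)nn2)CC1`: > 128000 nM
Compound 3 `COc1ccc(Cn2cc(CSC(=S)N3CCN(C(=O)NC(C)C)CC3)nn2)cc1`: > 128000 nM

In a functional assay on SMMC-7721 cells (Homo sapiens) for cytotoxicity, read by MTT assay, with a stated time of 72 h (a higher number here means a weaker inhibitor, a lower number a stronger inhibitor), compound 1 gives only a limit, > 128000 nM. Compound 2 likewise gives only a limit, > 128000 nM. Compound 3 also gives only a limit, > 128000 nM. All three values sit at the limit of > 128000 nM in this assay, at which 3 of the 3 values shown sit, so no order among them can be read. Compound 2 differs from compound 1 by ethyl(methyl)amino in place of isopropylamino on a carbonyl carbon, and the step that the two limits leave unreadable from compound 1 to compound 2 cannot be sized. Compound 3 differs from compound 1 by methoxy in place of methyl on an aromatic carbon, and a step that the two limits leave unreadable from compound 1 to compound 3 is equally unreadable.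

Compound 4 `CCN(C)C(=O)N1CCN(C(=S)SCc2cn(Cc3ccc(OC)cc3)nn2)CC1` has not yet been measured. It differs from compound 3 by ethyl(methyl)amino in place of isopropylamino on a carbonyl carbon, the same change as that from compound 1 to compound 2, now made on the core of compound 3 rather than on the core of compound 1. That earlier step left both of its compounds at the limit of > 128000 nM in this assay, at which 3 of the 3 values shown sit, and so the step that the limit leaves unreadable from compound 3 to compound 4 is expected to end at the limit as well. Compound 4 is therefore expected to give about 150000 nM, somewhere between 60000 nM and 400000 nM, most likely reported only as a limit.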

Compound 4, half-maximal inhibitory concentration: > 128000 nM
Compound 4 gave a limit, no number; the forecaster's own chance of this, stated with the estimate: 85%; the middle value is on the limit's open side.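

Compound 4 gives only a limit in this assay, so the steps from compound 3 to compound 4 and from compound 2 to compound 4 cannot be read, and no order among the four compounds can be drawn: the limit of > 128000 nM in this assay, at which 4 of the 4 values shown sit.

The compounds shown leave open whether ethyl(methyl)amino in place of isopropylamino, or methoxy in place of methyl, changes cytotoxicity at all.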